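The source may report more compounds than this note shows. Statements on the series, on what has been measured and on what is new or still open speak of the compounds shown alone.

Of the compounds shown here, three from one series have been tested in a functional assay on NCI-H460 cells (Homo sapiens) for cytotoxicity, read by MTT assay, with a stated time of 72 h; a higher number here means a weaker inhibitor, a lower number a stronger inhibitor. Compound 1 `COc1cccc(-c2cc(C(=O)Nc3ccc(Oc4ccnc5cc(OCCCN6CCCC6)c(OC)cc45)c(F)c3)c3ccccc3n2)c1` gives 290 nM in this assay. Compound 2 `COc1cc2c(Oc3ccc(NC(=O)c4cc(-c5ccc(C)cc5)nc5ccccc45)cc3F)ccnc2cc1OCCCN1CCCC1` differs from compound 1 in a single place, where the change is 4-methylphenyl in place of 3-methoxyphenyl on an aromatic carbon, and in this assay compound 2 gives 240 nM. That change made a step of a 1.2-fold lower number from compound 1 to compound 2 (0.08 log units; within the scatter). Compound 3 `COc1cccc(-c2cc(C(=O)Nc3ccc(Oc4ccnc5cc(OCCCN6CCCCC6)c(OC)cc45)c(F)c3)c3cc(F)ccc3n2)c1` carries a different core from compound 1; the difference between the two cores is not broken down here. In this assay compound 3 gives 1000 nM, the highest of the three numbers, and its distance from compound 1 and from compound 2 lies beyond the scatter in both cases.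

Compound 4 `COc1cc2c(Oc3ccc(NC(=O)c4cc(-c5ccc(C)cc5)nc5ccc(F)cc45)cc3F)ccnc2cc1OCCCN1CCCCC1` has not yet been measured in this assay. It stands to compound 3 as compound 2 stands to compound 1: the change is 4-methylphenyl in place of 3-methoxyphenyl on an aromatic carbon, and the surroundings of the place are described in the same words for both pairs, so it is the same change made on the other core. Compound 4 is expected to show a step of a 1.2-fold lower number from compound 3 to compound 4 (0.08 log units; within the scatter). This expectation rests on compound 1 and compound 2, whose step of a 1.2-fold lower number from compound 1 to compound 2 (0.08 log units; within the scatter) lay within the scatter. Whether the second core answers to the change in the same way is not yet known. Compound 4 is therefore estimated at 830 nM in this assay, with a likely range from 400 nM to 1700 nM.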

Compound 4, half-maximal inhibitory concentration: 260 nM
Compound 4: the middle estimate sits 3.2-fold (0.50 log units) above what was measured; the whole stated range lies above it.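

Carried to the core of compound 3 in this assay, the replacement of 3-methoxyphenyl by 4-methylphenyl gave a 3.8-fold lower number from compound 3 to compound 4 (0.59 log units; beyond the scatter), whereas on the core of compound 1 the same replacement gave a 1.2-fold lower number from compound 1 to compound 2 (0.08 log units; within the scatter). The change therefore did not carry over from one core to the other with a constant size, and the gap between the two steps is larger than repeated measurements would explain: the same change on two cores in this assay, a 1.2-fold lower number (0.08 log units; within the scatter) from compound 1 to compound 2 and a 3.8-fold lower number (0.59 log units; beyond the scatter) from compound 3 to compound 4, 3.2-fold (0.50 log units) apart, beyond the scatter of two such steps. Going by these compounds alone, with only one pair on each core, this shows that the size of the step depended on the core in these four compounds, but it does not show which difference between the two cores matters, or how a third core would respond.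

The compounds shown leave open whether the larger step on the core of compound 3 goes with the methyl group, with the place of the substituent on the phenyl ring, or with the loss of the methoxy group, and a 3-methylphenyl and a 4-methoxyphenyl group on both cores would separate these readings. They also leave open how an unsubstituted phenyl group or a phenyl ring carrying an amine would behave at this place on either core.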